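This account rests on a few compounds, and the source may have more. Where it says the series, first, only, none or still open, it means among the compounds named here.

Measured compounds:
compound 1, `COc1ccc(/C=N/c2c(C)n(C)n(-c3ccccc3)c2=O)cc1`: 575000000 nM
compound 2, `Cc1c(/N=C/c2cccc(O)c2)c(=O)n(-c2ccccc2)n1C`: 617000000 nM

Both compounds share one core and differ only in the aryl group on the carbon that carries the double bond to nitrogen. In a functional assay on HCT-116 cells (Homo sapiens) for cytotoxicity, read by MTT assay, with a stated time of 72 h (a lower number here means a stronger inhibitor, a higher number a weaker inhibitor), compound 1 gives 575000000 nM, and compound 2 gives 617000000 nM. Going by the values given here, the single step between them, a 1.1-fold higher number from compound 1 to compound 2 (0.03 log units; within the scatter), does not separate the two; compound 2 therefore stands next to compound 1 with no distinguishable difference, and both numbers point to very weak inhibition.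

Compound 3, `Cc1c(/N=C/c2cccc([N+](=O)[O-])c2)c(=O)n(-c2ccccc2)n1C`, has not been measured. Relative to compound 2 the change is nitro in place of hydroxy on an aromatic carbon. Among the compounds with values here, the only step that bears on this kind of change, an exchange of the substituent on the same aryl ring, is a 1.1-fold higher number from compound 1 to compound 2 (0.03 log units; within the scatter), which was within the scatter. On that basis no step beyond the scatter is expected for compound 3, and the change is estimated as a 1.0-fold lower number from compound 2 to compound 3 (0.01 log units; within the scatter). Compound 3 is thus expected to give about 600000000 nM in this assay, with a range of 300000000 nM to 1200000000 nM.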

Compound 3, half-maximal inhibitory concentration: 363000000 nM
The estimate for compound 3 lay 1.7-fold (0.22 log units) above the measured number; low and high end bracket the measured number.
By their numbers in this assay, from the lowest: compounds 3, 1 and 2 (each within the scatter of the next).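

Going by these compounds alone, compound 3 gives the first reading at this position in which only the substituent changes: on an aromatic carbon meta to a large group, nitro replaces hydroxy, and this assay shows a 1.7-fold lower number from compound 2 to compound 3 (0.23 log units; within the scatter). Thus, in this pair, replacing hydroxy, with 1 hydrogen-bond donor and 1 hydrogen-bond acceptor, by nitro, with 0 hydrogen-bond donors and 2 hydrogen-bond acceptors, gives no step beyond the scatter, a finding that the earlier step, with its change of aryl substituent, could not isolate. No supporting measurement is available to account for this result.

Open, going by these compounds, is whether an amine, a carboxylic acid or a longer chain such as butoxy on this same aromatic carbon would produce a step beyond the scatter in this assay. Also open, on these data alone, is whether a group such as chloro or methyl would behave like nitro and hydroxy here, and whether any change away from this aryl ring, on the shared core, would move the number further than these substituent exchanges have.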